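The source may report more compounds than this note shows. Statements on the series, on what has been measured and on what is new or still open speak of the compounds shown alone.

Measured so far:
compound 1, `Cc1cccc(-c2ccc(N(C[C@@H](N)CC(C)C)C(=O)[C@@H]3C[C@H]3c3ccccc3)cc2)c1` — 1200 nM in a functional assay for agonist activity at G protein-coupled receptor 88 (Homo sapiens), read by HTRF and cAMP accumulation; a higher number here means that more compound is needed for the effect, a lower number that less compound is needed
compound 2, `Cc1ccccc1-c1ccc(N(C[C@@H](N)CC(C)C)C(=O)[C@@H]2C[C@H]2c2ccccc2)cc1` — 3400 nM
compound 3, `COc1cccc(-c2ccc(N(C[C@@H](N)CC(C)C)C(=O)[C@@H]3C[C@H]3c3ccccc3)cc2)c1` — 1100 nM

Compound 3 gives the lowest number of the three, but the step of a 1.1-fold lower number from compound 1 to compound 3 (0.04 log units; within the scatter) is within the scatter, so these two cannot be ordered; compound 2 stands clearly apart (a 3.1-fold lower number from compound 2 to compound 3 (0.49 log units; beyond the scatter)).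

Compound 4, `COc1ccccc1-c1ccc(N(C[C@@H](N)CC(C)C)C(=O)[C@@H]2C[C@H]2c2ccccc2)cc1`, differs from compound 3 in one place: 2-methoxyphenyl in place of 3-methoxyphenyl on an aromatic carbon. The step that bears on this is the methyl analogue of the same move, a 2.8-fold higher number from compound 1 to compound 2 (0.45 log units; beyond the scatter), a modest loss. Since 3-methoxyphenyl and 3-methylphenyl gave alike numbers (a 1.1-fold lower number from compound 1 to compound 3 (0.04 log units; within the scatter)), a step of similar size and direction is expected here: a 2.7-fold higher number from compound 3 to compound 4 (0.44 log units; beyond the scatter). Compound 4 is therefore estimated at 3000 nM, with a range of 1200 nM to 8000 nM.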

Compound 4, half-maximal effective concentration: 3200 nM
For compound 4 the middle estimate is 1.1-fold (0.03 log units) below the measured one, and the stated range covers the measured number.
By their numbers in this assay, from the lowest: compounds 3 and 1 (each within the scatter of the next); then compounds 4 and 2 (each within the scatter of the next).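

The 2-methoxyphenyl group raises the number in this assay beyond the scatter, a 2.9-fold higher number from compound 3 to compound 4 (0.46 log units; beyond the scatter), so a loss on going to the 2-substituted ring now appears with methoxy as well as with methyl. On that ring the two groups cannot be told apart, a 1.1-fold lower number from compound 2 to compound 4 (0.03 log units; within the scatter), and the cross-comparison also shows a loss, a 2.7-fold higher number from compound 1 to compound 4 (0.43 log units; beyond the scatter). Methoxy for methyl reads the same in both settings: the same change on two cores in this assay, a 1.1-fold lower number (0.04 log units; within the scatter) from compound 1 to compound 3 and a 1.1-fold lower number (0.03 log units; within the scatter) from compound 2 to compound 4, 1.0-fold (0.01 log units) apart, within the scatter of two such steps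

Still open, on these data alone, is whether an amine or a carboxylic acid in place of methoxy would follow the same pattern on this ring.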